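A triazolylsulfanyl-to-hydroxy swap on a second sugar core

The source may hold more compounds than are shown below. What is called first, only, known or untested is meant among the compounds shown, and "the series" means these compounds.

In a functional assay on T47D cells (Homo sapiens) for antiproliferative activity, read by sulforhodamine B assay, with a stated time of 48 h (a lower number here means a stronger inhibitor of growth, a higher number a weaker inhibitor of growth), compound 3 `O=[N+]([O-])c1ccc(-c2nc(CO[C@@H]3O[C@H](CSc4ncn[nH]4)[C@H]4OC5(CCCC5)O[C@@H]34)no2)cc1` gives 20000 nM, and compound 1 `O=[N+]([O-])c1ccc(-c2nc(CO[C@@H]3O[C@H](CO)[C@H]4OC5(CCCC5)O[C@@H]34)no2)cc1` gives 50000 nM. The change between them is hydroxy in place of (1H-1,2,4-triazol-5-yl)sulfanyl on a saturated chain carbon bound to a saturated ring carbon, and it made a step of a 2.5-fold higher number from compound 3 to compound 1 (0.40 log units; beyond the scatter), so the hydroxy compound is the weaker growth inhibitor. Compound 2 `CC1(C)O[C@H]2[C@H](OCc3noc(-c4ccc([N+](=O)[O-])cc4)n3)O[C@H](CSc3ncn[nH]3)[C@H]2O1` carries the same (1H-1,2,4-triazol-5-yl)sulfanyl group on another core; how its core differs from that of compound 3 is not broken down here. In this assay compound 2 gives > 100000 nM, which is a limit of the assay and not a number. Compound 4 `CC1(C)O[C@H]2[C@H](OCc3noc(-c4ccc([N+](=O)[O-])cc4)n3)O[C@H](CO)[C@H]2O1` arises from compound 2 through the same change, (hydroxy in place of (1H-1,2,4-triazol-5-yl)sulfanyl on a saturated chain carbon bound to a saturated ring carbon). Because compound 2 already sits at the limit of > 100000 nM in this assay, at which 1 of the 3 values shown sits, and the same change weakened compound 1 relative to compound 3, compound 4 is expected to show a step that the limit leaves unreadable from compound 2 to compound 4 and an estimated value near 200000 nM, most likely again reported only as a limit.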

Compound 4, concentration for 50% growth inhibition: > 100000 nM
Compound 4 gave a limit, no number; the forecaster's own chance of this, stated with the estimate: 85%; the middle value lies beyond the limit too.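

In this assay compound 4 gives > 100000 nM, which is a limit of the assay and not a number. Compound 2 also stands at a limit, so no step can be read between compound 2 and compound 4. As far as these compounds go, whether the hydroxy swap weakens growth inhibition on the core of compound 2, as it does on the core of compound 3, stays open.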